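A few compounds are considered here, and "the series" means these few. Any claim that something is new, unique, unknown or untested is made for them only; others in the source may bear on it.

Measured compounds in an assay on FRT cells for positive allosteric modulation of Cystic fibrosis transmembrane conductance regulator variant N1303K (Homo sapiens), in the presence of a further agent that is not named here; on this read-out higher numbers stand for an effect only at larger amounts of compound and lower numbers for an effect already at smaller amounts:
- compound 1 `COc1ccc2[nH]c3c(c2c1)CCNC31CCN(Cc2ccccc2)CC1` gives 12600 nM
- compound 2 `COc1ccc2[nH]c3c(c2c1)CCNC31CCN(Cc2ccc(F)cc2F)CC1` gives 2000 nM
- compound 3 `COc1ccc2[nH]c3c(c2c1)CCNC31CCN(Cc2ccc(F)c(F)c2)CC1` gives 11000 nM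

Compound 3 stands second highest of the three numbers in this assay; its number lies within the scatter of compound 1 and is separated only from compound 2, which sits well lower.

The next step goes from compound 3 to compound 4 `COc1ccc2[nH]c3c(c2c1)CCNC31CCN(Cc2ccc(F)c(F)c2F)CC1`: fluoro in place of hydrogen on an aromatic carbon, the new fluoro entering ortho to a fluoro group and ortho to the large group, so that 3,4-difluorobenzyl becomes 2,3,4-trifluorobenzyl.

Going by the values given here, two measured steps bear on this. Fluoro at the position ortho to the large group is what sets compound 2 apart: a 6.3-fold lower number from compound 1 to compound 2 (0.80 log units; beyond the scatter) and a 5.5-fold higher number from compound 2 to compound 3 (0.74 log units; beyond the scatter), both modest and beyond the scatter. Adding fluoro at the other two positions did nothing: a 1.1-fold lower number from compound 1 to compound 3 (0.06 log units; within the scatter). Compound 4 carries the fluoro pattern of compound 2 plus one more fluoro already shown to be neutral, so the expected step in this assay is a modest lower number, a 2.8-fold lower number from compound 3 to compound 4 (0.44 log units; beyond the scatter).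

Compound 4 is therefore expected to give about 4000 nM, with a range from 1500 nM to 11000 nM.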

Compound 4, half-maximal effective concentration: 4100 nM
Compound 4: middle estimate off by 1.0-fold (0.01 log units), on the low side; the measured number falls inside the stated range.
By their numbers in this assay, from the lowest: compound 2; then compound 4; then compounds 3 and 1 (each within the scatter of the next).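

In this assay, fluoro on the aromatic carbon ortho to the large group still lowers the number when the ring already carries the 3,4-difluoro pattern (a 2.7-fold lower number from compound 3 to compound 4 (0.43 log units; beyond the scatter)), so this change is not tied to the 2,4-difluoro pattern of compound 2. The added fluoro is not neutral on that pattern either (a 2.1-fold higher number from compound 2 to compound 4 (0.31 log units; beyond the scatter)), even though the 3,4-difluoro pattern alone stays within the scatter of phenyl, and the 2,3,4-trifluorobenzyl group remains better than unsubstituted benzyl (a 3.1-fold lower number from compound 1 to compound 4 (0.49 log units; beyond the scatter)). Nothing available here accounts for these shifts.

Still open, on these data alone, is how a single fluoro ortho to the large group behaves with no other fluoro on the ring. Also open, as far as these compounds go, is whether that position accepts chloro, methyl or methoxy in place of fluoro.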